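Swapping piperidin-1-yl for benzylamino in compound 3

The source may report more compounds than this note shows. Statements on the series, on what has been measured and on what is new or still open speak of the compounds shown alone.

Values from a functional assay on U-937 cells (Homo sapiens) for antiproliferative activity, read by MTT assay, with a stated time of 24 h; on this read-out lower numbers stand for stronger inhibition and higher numbers for weaker inhibition:
Compound 1 `CCCCc1oc2ccccc2c1C(=O)c1ccc(OCCCC(=O)N[C@@H](C)c2ccccc2)cc1` gives 22400 nM
Compound 2 `CCCCc1oc2ccccc2c1C(=O)c1ccc(OCCCC(=O)N[C@H](C)c2ccccc2)cc1` gives 30700 nM
Compound 3 `CCCCc1oc2ccccc2c1C(=O)c1cc(I)c(OCCCN2CCCCC2)c(I)c1` gives 18200 nM

Compound 3 lies within the scatter of both compound 1 and compound 2, so the three cannot be ranked. Compound 4 `CCCCc1oc2ccccc2c1C(=O)c1cc(I)c(OCCCNCc2ccccc2)c(I)c1` carries benzylamino in place of piperidin-1-yl on a saturated chain carbon, three bonds along the chain from an oxygen on an aromatic ring. Among the compounds with values here, the only measured step, a 1.4-fold higher number from compound 1 to compound 2 (0.14 log units; within the scatter), concerns configuration alone (the fact that compounds 1 and 2 differ only in the configuration as drawn), so it says little about this swap. Taking compound 3 at 18200 nM as the anchor, no change beyond the scatter is expected in this assay (a 1.1-fold lower number from compound 3 to compound 4 (0.06 log units; within the scatter)). For compound 4 the estimated value is 16000 nM, with an expected range from 6500 nM to 35000 nM.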

Compound 4, half-maximal inhibitory concentration: 2300 nM
Estimate against measurement, compound 4: 7.0-fold (0.84 log units) above, outside the stated range (below it).
By their numbers in this assay, from the lowest: compound 4; then compounds 3, 1 and 2 (each within the scatter of the next).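

In this assay the swap from piperidin-1-yl to benzylamino gives a 7.9-fold lower number from compound 3 to compound 4 (0.90 log units; beyond the scatter) and so shows that the group at this saturated chain carbon can move the number beyond the scatter, which compounds 1 and 2 could not show. The swap changes several things at once, as a six-membered non-aromatic ring leaves, a six-membered aromatic ring of carbon only enters, and a hydrogen-bond donor appears. Nothing measured here accounts for the step.

As far as these compounds go, whether the aromatic ring or the amine hydrogen matters stays open. Cyclohexylmethylamino and N-methyl-N-benzylamino on the same chain would separate the two.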